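This account rests on a few compounds, and the source may have more. Where it says the series, first, only, none or still open, it means among the compounds named here.

Working notes on the series.

Compound 1 `Clc1ccc(CO/N=C/c2c(-c3cccc4ccccc34)nc3sccn23)cc1Cl` carries a naphthalen-1-yl group on the shared core. In an assay on HepG2 cells for agonist activity at nuclear receptor subfamily 1 group I member 3 (Homo sapiens), read by a luciferase reporter, with a stated time of 23 h (a lower number here means that less compound is needed, a higher number that more compound is needed for the effect), compound 1 gives 940 nM. Of the two numbers in hand, compound 1 stands at the higher one, but its nearest neighbour, compound 2 `FC(F)(F)c1ccc(CO/N=C/c2c(-c3ccc4ccccc4c3)nc3occn23)cc1`, lies within the usual scatter of it: in this assay compound 2 gives 470 nM. Compound 2 differs from compound 1 in more than one place, so no single step can be read off between them; the two values show only that both sit in the same general range.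

Compound 3 `Clc1ccc(CO/N=C/c2c(-c3ccc4ccccc4c3)nc3sccn23)cc1Cl` is the next point. It differs from compound 1 in one place: naphthalen-2-yl in place of naphthalen-1-yl on an aromatic carbon. For the measured compounds named here, no measured pair isolates this change, so the expectation rests on the two values seen and on the fact that compound 2, which also carries naphthalen-2-yl, sits at the lower of the two. A small move toward a lower number is expected for compound 3, but not one that clearly exceeds the scatter; the estimated step is a 1.4-fold lower number from compound 1 to compound 3 (0.16 log units; within the scatter). In this assay compound 3 is expected at about 650 nM, with a plausible range from 250 nM to 1700 nM.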

Compound 3, half-maximal effective concentration: 380 nM
Compound 3: the middle estimate sits 1.7-fold (0.23 log units) above what was measured, and the stated range covers the measured number.
By their numbers in this assay, from the lowest: compounds 3, 2 and 1 (each within the scatter of the next, the first and the last beyond it).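

For the compounds shown here, the swap of naphthalen-1-yl for naphthalen-2-yl on this aromatic carbon gives the first single-change comparison: in this assay it yields a 2.5-fold lower number from compound 1 to compound 3 (0.39 log units; beyond the scatter). Both groups have the same heavy-atom count, the same two six-membered aromatic rings of carbon only, and the same donor and acceptor counts, so this pair shows that the point of attachment alone can change the number at this position, although the step is modest and rests on one pair. No measurement at hand accounts for the difference between the two attachments, and the step stands here as an observation only.

It remains open whether a step of this size would also appear on the core of compound 2, for which only the naphthalen-2-yl form is shown. The compounds shown also leave open how this position would respond to a single phenyl ring, a quinolinyl group, or a phenyl ring carrying an amine or a carboxylic acid.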